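The source may hold more compounds than are shown below. What is called first, only, known or untested is meant among the compounds shown, and "the series" means these compounds.

In an ADME assay on Vero cells (Chlorocebus sabaeus) for cytotoxicity, read by CellTiter-Glo, with a stated time of 72 h (a higher number here means that more compound is tolerated, a lower number that less compound is tolerated), compound 1 `[O-][n+]1nc(NC2CC2)[n+]([O-])c2ccccc21` gives 21 ug/mL and compound 2 `CC(C)(C)Nc1n[n+]([O-])c2ccccc2[n+]1[O-]` gives 8 ug/mL while compound 3 `CCCC(C)Nc1n[n+]([O-])c2ccccc2[n+]1[O-]` gives 26 ug/mL and so stands within the scatter of compound 1 and clear of compound 2. Compound 4 `[O-][n+]1nc(N2CCCC2)[n+]([O-])c2ccccc21` carries pyrrolidin-1-yl in place of (1-methylbutyl)amino on an aromatic carbon, with the counted difference pyrrolidin-1-yl in place of (1-methylbutyl)amino on an aromatic carbon as the whole change. Going by the values given here, no measured step closes a ring through that nitrogen, so none covers this change directly. The nearest evidence is the swaps among the nitrogen substituents. The step of a 1.2-fold higher number from compound 1 to compound 3 (0.09 log units; within the scatter) lies within the scatter, whereas the steps of a 2.6-fold lower number from compound 1 to compound 2 (0.42 log units; beyond the scatter) and a 3.3-fold higher number from compound 2 to compound 3 (0.51 log units; beyond the scatter) are modest and both involve tert-butyl. Compound 4 has no tert-butyl, so no step beyond the scatter is expected in this assay for this change, though the expectation is loose. The expected step is a 1.2-fold lower number from compound 3 to compound 4 (0.07 log units; within the scatter) at the centre of the estimate. For compound 4 the estimated value is 22 ug/mL within an expected range of 9 ug/mL to 50 ug/mL in this series.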

Compound 4, half-maximal cytotoxic concentration: 17 ug/mL
Compound 4: middle estimate off by 1.3-fold (0.11 log units), on the high side, and the stated range covers the measured number.
By their numbers in this assay, from the lowest: compound 2; then compounds 4, 1 and 3 (each within the scatter of the next).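

In this assay, closing the substituent into a ring through the nitrogen, with no hydrogen-bond donor left there, gives a 1.5-fold lower number from compound 3 to compound 4 (0.18 log units; within the scatter) and a 1.2-fold lower number from compound 1 to compound 4 (0.09 log units; within the scatter) as its two steps, so among these compounds neither the ring nor the missing donor moves the number beyond the scatter. The tert-butyl compound is now set apart from all three others, and the pyrrolidin-1-yl group adds a 2.1-fold higher number from compound 2 to compound 4 (0.33 log units; beyond the scatter) as a further step beyond the scatter, making compound 2 the only one that breaks from the group. No measurement at hand gives a reason for this.

On these data alone, whether a six-membered ring such as piperidine or morpholine at this place would stay level with compound 4 remains open. So does the effect of a longer chain ending in an amine or a carboxylic acid.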